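The source may hold more compounds than are shown below. What is called first, only, known or untested is meant among the compounds shown, and "the series" means these compounds.

Measured so far in an assay on isolated protein for inhibition of Intestinal-type alkaline phosphatase (Bos taurus), read by spectrophotometry, with stated times of 7 min and 15 min; on this read-out lower numbers stand for stronger inhibition and higher numbers for weaker inhibition:

compound 1 `COc1ccc(Cn2c(-c3ccc(C)cc3)c(Br)c(=O)c3cc([N+](=O)[O-])ccc32)cc1`: 2430 nM
compound 2 `COc1ccc(Cn2c(-c3ccc(C)cc3)c(-c3ccc(C(F)(F)F)cc3)c(=O)c3cc([N+](=O)[O-])ccc32)cc1`: 8340 nM
compound 3 `Cc1ccc(-c2[nH]c3ccc([N+](=O)[O-])cc3c(=O)c2Br)cc1`: 12100 nM

Compound 3 shows the highest number of the three in this assay. Its gap to compound 2 lies within the scatter; its gap to compound 1 lies beyond it, as a 5.0-fold higher number from compound 1 to compound 3 (0.70 log units; beyond the scatter) records.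

Compound 4 `Cc1ccc(-c2[nH]c3ccc([N+](=O)[O-])cc3c(=O)c2-c2ccc(C(F)(F)F)cc2)cc1` has not been measured. Compared with compound 3 the difference is 4-(trifluoromethyl)phenyl in place of bromo on an aromatic carbon.

For the measured compounds named here, the one measured step that bears on this change is the same exchange on the core of compound 1, which gave a 3.4-fold higher number from compound 1 to compound 2 (0.54 log units; beyond the scatter). Going by the values given here, compound 3 and compound 4 share the core without the 4-methoxybenzyl group, so the step is taken from a different starting point, and only one precedent exists. On that precedent a modest rise in the number beyond the scatter is expected for compound 4, in the same direction as that precedent, namely a 3.1-fold higher number from compound 3 to compound 4 (0.50 log units; beyond the scatter).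

The estimate for compound 4 in this assay is therefore 38000 nM, with a range from 14000 nM to 110000 nM.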

Compound 4, half-maximal inhibitory concentration: 4380 nM
Compound 4: the middle estimate sits 8.7-fold (0.94 log units) above what was measured; measured number below the stated range.
By their numbers in this assay, from the lowest: compounds 1, 4, 2 and 3 (each within the scatter of the next, the first and the last beyond it).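

In this assay with hydrogen on the ring nitrogen, 4-(trifluoromethyl)phenyl in place of bromo gives a 2.8-fold lower number from compound 3 to compound 4 (0.44 log units; beyond the scatter) and so reverses the direction seen with 4-methoxybenzyl on that nitrogen; on this aromatic carbon, the exchange has no single direction across the two cores: the same change on two cores in this assay, a 3.4-fold higher number (0.54 log units; beyond the scatter) from compound 1 to compound 2 and a 2.8-fold lower number (0.44 log units; beyond the scatter) from compound 3 to compound 4, 9.5-fold (0.98 log units) apart, beyond the scatter of two such steps. With 4-(trifluoromethyl)phenyl on the carbon, hydrogen in place of 4-methoxybenzyl gives a 1.9-fold lower number from compound 2 to compound 4 (0.28 log units; within the scatter) and no longer separates the pair beyond the scatter, unlike the same exchange with bromo: the same change on two cores in this assay, a 5.0-fold higher number (0.70 log units; beyond the scatter) from compound 1 to compound 3 and a 1.9-fold lower number (0.28 log units; within the scatter) from compound 2 to compound 4, 9.5-fold (0.98 log units) apart, beyond the scatter of two such steps. Across these four compounds, the groups on the carbon and the nitrogen therefore do not act independently.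

On these data alone, whether this reversal is particular to 4-(trifluoromethyl)phenyl or also appears with a plain phenyl, an amine or a carboxylic acid on this carbon remains open. Also open, as far as these compounds go, is how a methyl or plain benzyl group on the ring nitrogen would behave with either group on the carbon.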